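The source may hold more compounds than are shown below. What is called first, only, known or untested is meant among the compounds shown, and "the series" means these compounds.

Compound 1, `COc1ccc2c(C3(c4c[nH]c5cc(OC)ccc45)C(=O)Nc4ccccc43)c[nH]c2c1`, gives 45400 nM.
Compound 2, `O=C1Nc2ccccc2C1(c1c[nH]c2ccc(Br)cc12)c1c[nH]c2ccc(Br)cc12`, gives 46800 nM.
Compound 3, `COc1ccc2c(C3(c4c[nH]c5cc(OC)ccc45)C(=O)Nc4ccc(F)cc43)c[nH]c2c1`, gives 12000 nM.

These three compounds were tested in a functional assay on MCF7 cells (Homo sapiens) for cytotoxicity, read by MTT assay, with a stated time of 48 h; a lower number here means a stronger inhibitor, a higher number a weaker inhibitor. Compound 1 and compound 3 share a core; the change from compound 1 to compound 3 is fluoro in place of hydrogen on an aromatic carbon, and it gave a 3.8-fold lower number from compound 1 to compound 3 (0.58 log units; beyond the scatter). The difference between the core of compound 1 and the core of compound 2 is not broken down here; their values lie close together. Compound 4, `O=C1Nc2ccc(F)cc2C1(c1c[nH]c2ccc(Br)cc12)c1c[nH]c2ccc(Br)cc12`, has not yet been measured. It differs from compound 2 by fluoro in place of hydrogen on an aromatic carbon, the same change at the same place as from compound 1 to compound 3. Because the earlier step was a 3.8-fold lower number from compound 1 to compound 3 (0.58 log units; beyond the scatter), a step of similar size is expected from compound 2 to compound 4 in this assay, namely a 3.3-fold lower number from compound 2 to compound 4 (0.52 log units; beyond the scatter). For compound 4 the expected value in this assay is 14000 nM, estimated to lie between 5000 nM and 40000 nM.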

Compound 4, half-maximal inhibitory concentration: 12800 nM
Compound 4: the middle estimate sits 1.1-fold (0.04 log units) above what was measured; the range from low to high includes it.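

In this assay fluoro in place of hydrogen on an aromatic carbon gave a 3.7-fold lower number from compound 2 to compound 4 (0.56 log units; beyond the scatter) on this second core as well. The change therefore carried over from one core to the other with much the same size: the same change on two cores in this assay, a 3.8-fold lower number (0.58 log units; beyond the scatter) from compound 1 to compound 3 and a 3.7-fold lower number (0.56 log units; beyond the scatter) from compound 2 to compound 4, 1.0-fold (0.01 log units) apart, within the scatter of two such steps. Going by these compounds alone, this rests on only two pairs of compounds, so it does not show that the step would hold on other cores, and it does not explain why the number falls.

On these data alone, it remains open whether another group at the same place, such as chloro, a nitrile or an amine, would give a similar step. As far as these compounds go, it is also open whether fluoro elsewhere on the molecule would do the same.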